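The source may report more compounds than this note shows. Statements on the series, on what has been measured and on what is new or still open speak of the compounds shown alone.

Compound 1 `CCOCc1c(C)coc1-c1ccc2c(c1OC)CCCC2(C)C` gives 17.7 uM in a functional assay on DU-145 cells (Homo sapiens) for cytotoxicity, read by sulforhodamine B assay, with a stated time of 3 days; a lower number here means that less compound is needed, a higher number that more compound is needed for the effect. Among the compounds with values here, compound 2 `COc1c(-c2occ(C)c2C(=O)O)ccc2c1CCCC2(C)C` gives 34.1 uM and holds the highest of the two numbers; its only neighbour is compound 1, and the step of a 1.9-fold higher number from compound 1 to compound 2 (0.28 log units; within the scatter) is the one measured change. Compound 3 `COc1c(-c2occ(C)c2COC(C)=O)ccc2c1CCCC2(C)C` differs from compound 2 by acetoxymethyl in place of carboxy on an aromatic carbon. That step lies within the scatter, so little beyond it is expected here; the acetoxymethyl group resembles the ethoxymethyl of compound 1 more than the carboxy of compound 2. Compound 3 is therefore estimated at 20 uM, with a range from 8 uM to 50 uM, meaning an expected step of a 1.7-fold lower number from compound 2 to compound 3 (0.23 log units; within the scatter).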

Compound 3, concentration for half-maximal effect: 16.7 uM
Beside the measured number, compound 3's estimate is 1.2-fold (0.08 log units) above it; low and high end bracket the measured number.
By their numbers in this assay, from the lowest: compounds 3, 1 and 2 (each within the scatter of the next, the first and the last beyond it).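

In this assay, acetoxymethyl in place of carboxy at this position gives a 2.0-fold lower number from compound 2 to compound 3 (0.31 log units; beyond the scatter), a modest step that is just beyond the scatter, whereas the earlier step between ethoxymethyl and carboxy stayed within it. Acetyl in place of ethyl on the side-chain oxygen gives a 1.1-fold lower number from compound 1 to compound 3 (0.03 log units; within the scatter), so these two side chains cannot be told apart here. Nothing available explains either step. The compounds shown leave open how a hydroxymethyl, an amine or a longer chain would read at this position. They also leave open whether a primary amide would fall nearer carboxy or acetoxymethyl.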